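Hydroxy added to the benzyl ring of compound 1

The source may report more compounds than this note shows. Statements on the series, on what has been measured and on what is new or still open speak of the compounds shown alone.

Measured so far:
compound 1 `O=C(NCC(=O)N1[C@@H](c2ccccc2O)CC[C@H]1C(=O)O)[C@@H](S)Cc1ccccc1` — 1 nM
compound 2 `Cc1ccccc1[C@H]1CC[C@@H](C(=O)O)N1C(=O)CNC(=O)[C@@H](S)Cc1ccccc1` — 5.3 nM

In an assay on isolated protein for inhibition of Neprilysin (Oryctolagus cuniculus) (on this read-out higher numbers stand for weaker inhibition and lower numbers for stronger inhibition), compound 1 gives 1 nM, the lowest of the two numbers to hand. Compound 2 gives 5.3 nM. Among the compounds with values here, the only measured step, a 5.3-fold higher number from compound 1 to compound 2 (0.72 log units; beyond the scatter), comes from methyl in place of hydroxy on an aromatic carbon of the ring that sits on the shared core.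

Compound 3 `O=C(NCC(=O)N1[C@@H](c2ccccc2O)CC[C@H]1C(=O)O)[C@@H](S)Cc1ccc(O)cc1` differs from compound 1 by hydroxy in place of hydrogen on an aromatic carbon. Within the data shown here, this change sits on the benzyl ring next to the thiol-bearing carbon, a part of the molecule no measured step touches. The step from compound 1 to compound 2 shows that a hydroxy on the other aromatic ring matters, but it says nothing about the benzyl ring. Among the measured compounds shown here, with no step bearing on it, a small step is expected for compound 3, a 1.5-fold higher number from compound 1 to compound 3 (0.18 log units; within the scatter), within the scatter and with no preferred direction.

In this assay compound 3 is therefore estimated at 1.5 nM, with a range from 0.5 nM to 5 nM.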

Compound 3, half-maximal inhibitory concentration: 3.5 nM
The estimate for compound 3 lay 2.3-fold (0.37 log units) below the measured number; low and high end bracket the measured number.
By their numbers in this assay, from the lowest: compound 1; then compounds 3 and 2 (each within the scatter of the next).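

In this assay, the benzyl ring is not a silent part of the molecule: going from benzyl to 4-hydroxybenzyl gives a 3.5-fold higher number from compound 1 to compound 3 (0.54 log units; beyond the scatter), so this position responds to the added hydroxy. Alongside a 5.3-fold higher number from compound 1 to compound 2 (0.72 log units; beyond the scatter), changes on both aromatic rings of compound 1 have now raised the number beyond the scatter, and compound 1 keeps the lowest number of the three. No measurement at hand bears on what lies behind the step from benzyl to 4-hydroxybenzyl.

As far as these compounds go, it remains open whether this step is specific to hydroxy or would also appear with another group at the same place, such as a methoxy, an amine or a fluorine on the benzyl ring of compound 1. Also open, from the compounds shown here alone, are whether a hydroxy elsewhere on the benzyl ring would give a step of similar size, and whether the 4-hydroxybenzyl change would read the same on the methyl-bearing ring of compound 2.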